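Benzyl for cyclohexyl on the amine nitrogen

The source may report more compounds than this note shows. Statements on the series, on what has been measured and on what is new or still open speak of the compounds shown alone.

Measured in an ADME assay on THP-1 cells (Homo sapiens) for cytotoxicity, read by trypan blue exclusion, with a stated time of 48 h; on this read-out higher numbers stand for weaker inhibition of growth and lower numbers for stronger inhibition of growth:
- compound 1 `Cc1cc(/C=N\OCc2ccccc2)c(C)n1-c1ccc(Cl)cc1` gives 500 ug/mL
- compound 2 `Cc1cc(CNC2CCCCC2)c(C)n1-c1ccc(Cl)cc1` gives 7.4 ug/mL

Of the two numbers, compound 2 holds the lower, 7.4 ug/mL. Compound 1 stands at 500 ug/mL. The gap between these two numbers lies beyond the scatter. Compound 3 `Cc1cc(CNCc2ccccc2)c(C)n1-c1ccc(Cl)cc1` has benzyl in place of cyclohexyl on an amine nitrogen. For the measured compounds named here, no measured pair isolates this change, so the expectation rests on compound 2 alone at 7.4 ug/mL. In this assay, no step beyond the scatter is expected, in either direction. The expected change is a 1.4-fold higher number from compound 2 to compound 3 (0.13 log units; within the scatter). For compound 3 the estimated value is 10 ug/mL, with an expected range of 4 ug/mL to 30 ug/mL.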

Compound 3, concentration for 50% growth inhibition: 7.2 ug/mL
The estimate for compound 3 lay 1.4-fold (0.14 log units) above the measured number, and the stated range covers the measured number.
By their numbers in this assay, from the lowest: compounds 3 and 2 (each within the scatter of the next); then compound 1.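

Benzyl in place of cyclohexyl on the amine nitrogen gives no step beyond the scatter in this assay (a 1.0-fold lower number from compound 2 to compound 3 (0.01 log units; within the scatter)). At this position, the read-out does not tell the six-membered non-aromatic ring from the aromatic one. Nothing in hand explains this match.

On these data alone, it remains open whether a ring is needed on this nitrogen at all, since an open chain such as n-butyl could read differently. Also open, as far as these compounds go, is what a benzyl carrying a carboxylic acid, or an amide in place of the amine, would give.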